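Cyclohexanecarboxamide series: cytotoxicity limits and a pyridyl variant

The compounds below may be only part of what the source reports. "The series", "measured", "known", "first", "only" and "open" are said of these compounds alone.

compound 1 `O=C(Nc1ccc2nc(NC(=O)C3CCCCC3)sc2c1)c1ccc(Br)cc1` — in a functional assay on WI-38 VA13 cells (Homo sapiens) for cytotoxicity (on this read-out higher numbers stand for an effect only at larger amounts of compound and lower numbers for an effect already at smaller amounts), compound 1 gives only the limit > 4 ug/mL.
compound 2 `O=C(Nc1ccc2nc(NC(=O)C3CCCCC3)sc2c1)c1ccc(Cl)cc1Cl` — in this assay compound 2 gives only the limit > 4 ug/mL.

Compound 2 therefore stands at a limit, not at a number. The step that the two limits leave unreadable from compound 1 to compound 2 cannot be read, since both values sit at the limit of > 4 ug/mL in this assay, at which 2 of the 2 values shown sit. Compound 3 `O=C(Nc1ccc2nc(NC(=O)C3CCCCC3)sc2c1)c1cccnc1Cl` differs from compound 2 by 2-chloropyridin-3-yl in place of 2,4-dichlorophenyl on a carbonyl carbon. Going by the values given here, no measured step bears on this change. With both measured values at the limit, compound 3 is expected to sit near that same limit, a step that the limit leaves unreadable from compound 2 to compound 3 not beyond the scatter. The estimate for compound 3 in this assay is 6 ug/mL, with a range from 3 ug/mL to 20 ug/mL.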

Compound 3, half-maximal effective concentration: 0.075 ug/mL
Estimate against measurement, compound 3: 80-fold (1.90 log units) above; measured number outside the range, below it.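

Placing 2-chloropyridin-3-yl on the carbonyl carbon gives an at least 53-fold lower number from compound 2 to compound 3 (1.72 log units; beyond the scatter) in this assay, and the same group against 4-bromophenyl gives an at least 53-fold lower number from compound 1 to compound 3 (1.72 log units; beyond the scatter). This position can therefore move the read-out far, which the two phenyl compounds alone did not show. Both sizes are bounds rather than exact steps, because compound 1 and compound 2 stop at a limit: the limit of > 4 ug/mL in this assay, at which 2 of the 3 values shown sit.

The compounds shown do not tell whether the ring nitrogen or the change in chlorine substitution carries the step. Unsubstituted pyridin-3-yl or 2-chlorophenyl on the same carbonyl carbon would separate the two.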